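This account rests on a few compounds, and the source may have more. Where it says the series, first, only, none or still open, it means among the compounds named here.

Compound 2 `CCc1ccc2[nH]c(=O)c(CN(Cc3ccc(C(C)(C)C)cc3)[C@H](CO)c3ccccc3)cc2c1` and compound 1 `CCc1ccc2[nH]c(=O)c(CN(Cc3ccc(OCOC)cc3)Cc3ccc(C(C)(C)C)cc3)cc2c1` share the same core. In a toxicity assay on MDCK cells (Canis lupus familiaris) for cytotoxicity, read by crystal violet staining, with a stated time of 48 h (a higher number here means that more compound is tolerated, a lower number that less compound is tolerated), compound 2 gives > 10000 nM, which is a limit of the assay. In this assay compound 1 gives > 10000 nM, also a limit. The step that the two limits leave unreadable from compound 1 to compound 2 is therefore not readable; (the limit of > 10000 nM in this assay, at which 2 of the 2 values shown sit). Compound 3 `CCc1ccc2[nH]c(=O)c(CN(Cc3ccc(C(C)(C)C)cc3)C(C)c3ccc(F)cc3)cc2c1` differs from compound 2 by 1-(4-fluorophenyl)ethyl in place of 2-hydroxy-1-phenylethyl on an amine nitrogen. For the measured compounds named here, no measured step bears on this change, so no shift beyond the scatter is expected, and the expected step that the limit leaves unreadable from compound 2 to compound 3 rests on the limits alone. Compound 3 is estimated at 15000 nM in this assay, range 5000 nM to 50000 nM, most likely again reported only as a limit.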

Compound 3, half-maximal cytotoxic concentration: 2800 nM
For compound 3 the middle estimate is 5.4-fold (0.73 log units) above the measured one; measured number below the stated range.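

In this assay, compound 3 is the first compound shown with a number rather than a limit, so the group on this amine nitrogen can lower the tolerated concentration. 1-(4-fluorophenyl)ethyl gives an at least 3.5-fold lower number from compound 2 to compound 3 (0.55 log units; beyond the scatter), and it also gives an at least 3.5-fold lower number from compound 1 to compound 3 (0.55 log units; beyond the scatter). Both sizes are minimums, and the step between compound 1 and compound 2 cannot be read: the limit of > 10000 nM in this assay, at which 2 of the 3 values shown sit.

Still open, as far as these compounds go, is whether the step follows the fluorine or the loss of the hydroxyl of 2-hydroxy-1-phenylethyl. Plain 1-phenylethyl on this nitrogen would separate the two, and the single enantiomers of 1-(4-fluorophenyl)ethyl would test the stereocentre.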